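Series notes: benzothiophene for benzoyl on the thioether arm

A few compounds are considered here, and "the series" means these few. Any claim that something is new, unique, unknown or untested is made for them only; others in the source may bear on it.

Two members of this series have been tested so far. Compound 1 `Cc1cc(Nc2ccn(Cc3cccc4ccccc34)n2)n2nc(SCc3ccc(Br)cc3)nc2n1` gives 30000 nM in an ADME assay on GES1 cells (Homo sapiens) for inhibition, read by MTT assay, with a stated time of 72 h; on this read-out higher numbers stand for weaker inhibition and lower numbers for stronger inhibition. Compound 2 `Cc1cc(Nc2cc(-c3ccccc3)[nH]n2)n2nc(SCC(=O)c3ccccc3)nc2n1` gives 33300 nM in this assay, the larger of the two numbers, yet the gap to compound 1 is within the usual scatter, so the two cannot be told apart. Both sit at the weak end of inhibition.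

Compound 3 `Cc1cc(Nc2cc(-c3ccccc3)[nH]n2)n2nc(SCc3csc4ccccc34)nc2n1` has not been measured in this assay. It differs from compound 2 by 1-benzothiophen-3-yl in place of benzoyl on a saturated chain carbon bound to a sulfur. Going by the values given here, no step between measured pairs exists to rest on; the two numbers known merely show that this part of the molecule, bromobenzyl in compound 1 against benzoylmethyl in compound 2, did not move the read-out beyond scatter. The expected step is therefore none beyond the scatter, estimated as a 1.1-fold lower number from compound 2 to compound 3 (0.05 log units; within the scatter). Compound 3 is estimated at 30000 nM, with a range from 12000 nM to 80000 nM.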

Compound 3, half-maximal inhibitory concentration: 29200 nM
Compound 3: middle estimate off by 1.0-fold (0.01 log units), on the high side; the range from low to high includes it.
By their numbers in this assay, from the lowest: compounds 3, 1 and 2 (each within the scatter of the next).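

On the saturated chain carbon bound to a sulfur, 1-benzothiophen-3-yl in place of benzoyl gives a 1.1-fold lower number from compound 2 to compound 3 (0.06 log units; within the scatter) in this assay. Going by these compounds alone, this is the first step with only one place changed, and it shows that compound 2 and compound 3 cannot be told apart on this read-out, with the carbonyl of benzoyl present in the former and absent from the latter. No measurement at hand explains this result.

Still open, from the compounds shown here alone, is whether an amine or a carboxylic acid on this arm, or a longer chain from the sulfur to the aromatic group, would give a step beyond the scatter. Going by these compounds, with a single step to read, the response of the read-out to a change elsewhere on the shared core also remains open.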